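The source may report more compounds than this note shows. Statements on the series, on what has been measured and on what is new or still open speak of the compounds shown alone.

Measured so far in an ADME assay on HepG2 cells (Homo sapiens) for cytotoxicity, read by MTT assay, with a stated time of 72 h; on this read-out lower numbers stand for higher toxicity in this test and higher numbers for lower toxicity in this test:
compound 1 (`O=[N+]([O-])c1c(CS(=O)(=O)c2ccccc2)nc2c(C#Cc3cccc(F)c3)cc(Cl)cn12`) gives > 3900 nM as a limit
compound 2 (`O=[N+]([O-])c1c(CS(=O)(=O)c2ccccc2)nc2c(C#Cc3ccccc3F)cc(Cl)cn12`) gives > 3900 nM as a limit
compound 3 (`O=[N+]([O-])c1c(CS(=O)(=O)c2ccccc2)nc2c(C#CCOc3ccccc3)cc(Cl)cn12`) gives 8400 nM as a number

Going by the values given here, compound 3 holds the only true number in this set. The other two entries sit at one limit (the limit of > 3900 nM in this assay, at which 2 of the 3 values shown sit) and cannot be ranked against it.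

Compound 4 (`O=[N+]([O-])c1c(CS(=O)(=O)c2ccccc2)nc2c(C#CCCO)cc(Cl)cn12`) departs from compound 3 in one place (hydroxymethyl in place of phenoxy on a saturated chain carbon bound to a triple-bonded carbon) with hydroxymethyl in place of phenoxy on a saturated chain carbon bound to a triple-bonded carbon. Cut one bond further out, the same difference reads phenoxymethyl to 2-hydroxyethyl.

Two measured steps change the group on the triple-bonded carbon and reach compound 3, yet neither yields a size (a step that the limit leaves unreadable from compound 1 to compound 3 and a step that the limit leaves unreadable from compound 2 to compound 3) for comparison. The remaining measured step (a step that the two limits leave unreadable from compound 1 to compound 2) gives no size either. Among the compounds with values here, no measured step alters the phenoxy group itself, so no direction can be read from the data in this assay and no step beyond the scatter is expected. The expectation therefore rests on compound 3 at 8400 nM alone. The expected step is a 1.4-fold higher number from compound 3 to compound 4 (0.15 log units; within the scatter) with wide uncertainty. Compound 4 is estimated at 12000 nM with an expected range from 4000 nM to 40000 nM as a working figure.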

Compound 4, half-maximal cytotoxic concentration: > 125000 nM
Compound 4 was reported as a limit (the forecaster's own chance of this, stated with the estimate: 40%); middle value at least 10-fold (1.01 log units) from the limit.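

In this assay, compound 4 gives > 125000 nM, which is a limit and not a number: the limit of > 125000 nM in this assay, at which 1 of the 4 values shown sits.

Hydroxymethyl in place of phenoxy on a saturated chain carbon bound to a triple-bonded carbon gives an at least 14-fold higher number from compound 3 to compound 4 (1.17 log units; beyond the scatter), the only readable step in the set, and it shows that the read-out at this position responds to the group carried there. The other steps in the set, including those linking compound 1 and compound 2 to compound 4, cannot be read.

The readable step removes the six-membered aromatic ring and brings in a hydrogen-bond donor together, so the compounds shown do not separate these two changes. On these data alone, a 2-methoxyethyl or 2-aminoethyl group in place of 2-hydroxyethyl would bear on that question, while the full size of the step remains open.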